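This account rests on a few compounds, and the source may have more. Where it says the series, first, only, none or still open, it means among the compounds named here.

Compound 1 `C=CCN(CC=C)Cc1c(C(F)(F)F)nc2n(-c3c(C)cc(C)cc3C)c(Cl)cn12` gives 13 nM in an assay on cells for displacement of a labelled ligand from corticotropin-releasing factor receptor 1 (Homo sapiens), with a stated time of 100 min; a lower number here means a stronger inhibitor, a higher number a weaker inhibitor. Compound 2 `Cc1cc(C)c(-n2c(Cl)cn3c(CN4CCC(c5ccccc5)C4)c(C(F)(F)F)nc23)c(C)c1` gives 610 nM in this assay, and the only measured step, a 47-fold higher number from compound 1 to compound 2 (1.67 log units; beyond the scatter), makes compound 2 the higher of the two numbers shown. Compound 3 `Cc1cc(C)c(-n2c(Cl)cn3c(CN4CCCCC4)c(C(F)(F)F)nc23)c(C)c1` differs from compound 2 in one place: piperidin-1-yl in place of 3-phenylpyrrolidin-1-yl on a saturated chain carbon bound to an aromatic carbon. Going by the values given here, the single relevant step, a 47-fold higher number from compound 1 to compound 2 (1.67 log units; beyond the scatter), shows that a large group on that chain carbon went with a much higher number; removing it is therefore expected to lower the number, and the step of a 10-fold lower number from compound 2 to compound 3 (1.01 log units; beyond the scatter) is estimated. For compound 3 the expected value in this assay is 60 nM, with a range from 15 nM to 300 nM.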

Compound 3, inhibition constant: 1200 nM
Estimate against measurement, compound 3: 20-fold (1.30 log units) below, outside the stated range (above it).
By their numbers in this assay, from the lowest: compound 1; then compounds 2 and 3 (each within the scatter of the next).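

In this assay, piperidin-1-yl in place of 3-phenylpyrrolidin-1-yl gives a 2.0-fold higher number from compound 2 to compound 3 (0.29 log units; within the scatter), so these two ring amines cannot be told apart here, although piperidin-1-yl has fewer heavy atoms and no phenyl ring. The large gap to diallylamino therefore remains with the smaller ring too, as shown by a 92-fold higher number from compound 1 to compound 3 (1.97 log units; beyond the scatter) in this comparison. Still open, going by these compounds, is whether diethylamino, an open-chain amine without the allyl double bonds, or pyrrolidin-1-yl without its phenyl ring would match diallylamino. No evidence here explains the gap between diallylamino and the two ring amines.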